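Ring Swap on the Thiocarbonyl Carbon of Compound 3

The source may report more compounds than this note shows. Statements on the series, on what has been measured and on what is new or still open speak of the compounds shown alone.

Three compounds sharing one core were measured in a functional assay on HeLa cells (Homo sapiens) for antiproliferative activity, read by CCK-8 assay, with a stated time of 72 h, tested at 8 uM; a lower number here means a weaker effect, a higher number a stronger effect of the compound at the concentration tested. Compound 1 `Nc1ccccc1NC(=O)c1ccc(CSC(=S)N2CCN(c3ccccc3)CC2)cc1` gives 73.1% in this assay. Compound 2 `Nc1ccccc1NC(=O)c1ccc(CSC(=S)N2CCc3ccccc32)cc1` gives 67%. Compound 3 `CC1CCCCN1C(=S)SCc1ccc(C(=O)Nc2ccccc2N)cc1` gives 76.3%, the highest of the three numbers, though its gaps to compound 1 and to compound 2 both lie within the scatter. For the measured compounds named here, the only step between compounds that differ in one place, a number 9.3 percentage points higher from compound 2 to compound 3 (within the scatter), is likewise within the scatter.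

Compound 4 `CN1CCN(C(=S)SCc2ccc(C(=O)Nc3ccccc3N)cc2)CC1` has not yet been measured. It differs from compound 3 in one place: 4-methylpiperazin-1-yl in place of 2-methylpiperidin-1-yl on a thiocarbonyl carbon. Going by the values given here, the only measured step that bears on an exchange at the thiocarbonyl carbon is a number 9.3 percentage points higher from compound 2 to compound 3 (within the scatter), which stayed within the scatter; compound 1, carrying yet another ring at that place, also sits within the scatter of compound 3. No measured compound carries a 4-methylpiperazin-1-yl group, so nothing shown speaks to that ring itself. One therefore expects no step beyond the scatter in this assay, and the estimated step is a number 4.3 percentage points lower from compound 3 to compound 4 (within the scatter). Compound 4 is estimated to give 72%, with an expected range from 58% to 84%.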

Compound 4, a percentage reported as inhibition, at one concentration (the size of the read-out at that concentration, not a potency): 75.7%
Compound 4: middle estimate off by 3.7 percentage points, on the low side, within the range that was stated.
By their numbers in this assay, from the lowest: compounds 2, 1, 4 and 3 (each within the scatter of the next).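

In this assay, 4-methylpiperazin-1-yl in place of 2-methylpiperidin-1-yl on a thiocarbonyl carbon gives a number 0.6 percentage points lower from compound 3 to compound 4 (within the scatter), so a second hetero atom in the six-membered ring and a hydrogen-bond acceptor count of 1 rather than 0 come with no step beyond the scatter. For the compounds shown here, the new ring also gives the first view of a change on the amine nitrogen in a ring, where methyl in place of phenyl gives a number 2.6 percentage points higher from compound 1 to compound 4 (within the scatter), and the exchange of 2,3-dihydro-1H-indol-1-yl for the same ring gives a number 8.7 percentage points higher from compound 2 to compound 4 (within the scatter), so compound 4 lies within the scatter of all three earlier compounds. No measurement shown offers a reason for any of these steps.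

The read-out comes from a single concentration, so it leaves open whether these four compounds would separate in potency. From the compounds shown here alone, it is also open whether a diethylamino group on a thiocarbonyl carbon, or a hydrogen or a longer chain in place of the methyl on the amine nitrogen in a ring, would produce a step beyond the scatter.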